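Moving the halogen again on the ring-nitrogen phenyl

The compounds below may be only part of what the source reports. "The series", "measured", "known", "first", "only" and "open" are said of these compounds alone.

Three pyrazolines with the shared core of compound 1 `CC(C)(C)C1=NN(c2cccc(Cl)c2)C(c2ccc(O)cc2)C1` have been measured in an assay on isolated protein for inhibition of protein kinase C zeta type (Homo sapiens), with a stated time of 4 min, tested at 62.5 uM; on this read-out higher numbers stand for more inhibition at the one concentration tested (going by the name of the read-out) and lower numbers for less inhibition. Compound 1 gives 96.8%, compound 2 `CC(C)(C)C1=NN(c2cccc(F)c2)C(c2ccc(O)cc2)C1` gives 98.1%, and compound 3 `CC(C)(C)C1=NN(c2ccccc2F)C(c2ccc(O)cc2)C1` gives 57.6%, the lowest of the three numbers; the step of a number 39.2 percentage points lower from compound 1 to compound 3 (beyond the scatter) and the step of a number 40.5 percentage points lower from compound 2 to compound 3 (beyond the scatter) are both large, while the step of a number 1.3 percentage points higher from compound 1 to compound 2 (within the scatter) is within the scatter. Compound 4 `CC(C)(C)C1=NN(c2ccc(Cl)cc2Cl)C(c2ccc(O)cc2)C1` is not yet measured. It differs from compound 3 by 2,4-dichlorophenyl in place of 2-fluorophenyl on an amine nitrogen in a ring. Going by the values given here, the two large steps that bear on this change are those in which the halogen of the phenyl was moved from the place it has in 3-chlorophenyl or 3-fluorophenyl to the place it has in 2-fluorophenyl; compound 4 keeps a halogen in that latter place and adds a second chlorine for which no measured step exists. In this assay compound 4 is therefore expected to stay near compound 3, with the step of a number 2.4 percentage points higher from compound 3 to compound 4 (within the scatter) estimated to lie within the scatter, and its value is estimated at 60%, between 30% and 90%.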

Compound 4, a percentage reported as inhibition, at one concentration (the size of the read-out at that concentration, not a potency): 71%
Estimate against measurement, compound 4: 11 percentage points below, within the range that was stated.
By their numbers in this assay, from the lowest: compound 3; then compound 4; then compounds 1 and 2 (each within the scatter of the next).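

In this assay, the 2,4-dichlorophenyl group gives a number above that of the 2-fluorophenyl group, with a step of a number 13.4 percentage points higher from compound 3 to compound 4 (beyond the scatter), so a halogen kept in that place does not by itself hold the number at the level of compound 3. The number still falls short of those with one halogen in the 3-chlorophenyl or 3-fluorophenyl group, with steps of a number 25.8 percentage points lower from compound 1 to compound 4 (beyond the scatter) and a number 27.1 percentage points lower from compound 2 to compound 4 (beyond the scatter), both modest. No measurement presented here accounts for these differences.

This change swaps fluorine for chlorine and adds a second chlorine at once, so the compounds shown do not tell how much of the step belongs to each. Going by these compounds, how a methoxy group or an amine on this phenyl ring would read in place of the halogens also remains open.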